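The source may report more compounds than this note shows. Statements on the series, on what has been measured and on what is new or still open speak of the compounds shown alone.

Compound 1 `COc1ccc(/C=C/C(=O)c2c(OC)cc(O)c(CC=C(C)C)c2O)cc1`: 32400 nM
Compound 2 `COc1cc(OC)c(OC)cc1/C=C/C(=O)c1c(OC)cc(O)c(CC=C(C)C)c1O`: > 50000 nM
Compound 3 `COc1cc(/C=C/C(=O)c2c(OC)cc(O)c(CC=C(C)C)c2O)cc(OC)c1OC`: > 50000 nM

Among the compounds with values here, in a functional assay on HepG2 cells (Homo sapiens) for inhibition, read by MTT assay, with a stated time of 72 h (on this read-out lower numbers stand for stronger inhibition and higher numbers for weaker inhibition), compound 1 gives 32400 nM, the only actual number among the three compounds. Compound 2 reads > 50000 nM, which is a limit of the assay and not a number. Compound 3 reads > 50000 nM, again a limit. The series thus rests on one number and on (the limit of > 50000 nM in this assay, at which 2 of the 3 values shown sit).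

Compound 4 `COc1cc(O)c(CC=C(C)C)c(O)c1C(=O)/C=C/c1ccc(Cl)cc1` keeps the shared core and changes one group: chloro in place of methoxy on an aromatic carbon. This is chloro in place of methoxy on an aromatic carbon, para to a large group, or 4-methoxyphenyl to 4-chlorophenyl. Within the data shown here, no measured pair shows this change, so the expectation starts from compound 1 at 32400 nM. Only a small move toward stronger inhibition is expected, one that stays within the usual scatter. The estimated change is a 1.2-fold lower number from compound 1 to compound 4 (0.10 log units; within the scatter). For compound 4 the expected value is 26000 nM, with an estimated range from 11000 nM to 50000 nM.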

Compound 4, half-maximal inhibitory concentration: 10100 nM
Estimate against measurement, compound 4: 2.6-fold (0.41 log units) above, and the stated range ends above it.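

In this assay, chloro in place of methoxy on an aromatic carbon, para to a large group, gives a 3.2-fold lower number from compound 1 to compound 4 (0.51 log units; beyond the scatter). This shows that the position responds to this change by more than the usual scatter, and that the 4-methoxyphenyl group is not required for the inhibition seen with compound 1. It is also the only step in the series that can be read, because the other values are limits and not numbers: the limit of > 50000 nM in this assay, at which 2 of the 4 values shown sit.

From the compounds shown here alone, what remains open is whether this step is specific to chloro or would also appear with another group in place of methoxy, such as bromo, an amine or a carboxylic acid. The compounds shown also leave open whether the same change would have a similar effect on another carbon of that ring.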